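The source may report more compounds than this note shows. Statements on the series, on what has been measured and on what is new or still open speak of the compounds shown alone.

Measured so far in a functional assay on ECV-304 cells (Homo sapiens) for cytotoxicity, read by MTT assay, with stated times of 24 h and 12 h; a higher number here means that more compound is needed for the effect, a lower number that less compound is needed:
compound 1 `CCOC(=O)/C=C/c1cccc(OCc2nc(C)c(C)nc2C)c1` gives 4330000 nM
compound 2 `Cc1nc(C)c(COc2ccc(/C=C/C(=O)O)cc2)nc1C` gives 86000 nM

Compound 1 holds the higher of the two numbers, and the gap down to compound 2 lies beyond the scatter. Compound 3 `Cc1nc(C)c(COc2cccc(/C=C/C(=O)O)c2)nc1C` has not yet been measured. It differs from compound 1 by hydrogen in place of ethyl on an oxygen next to a carbonyl group, which reads as ethoxycarbonyl to carboxy (hydrogen in place of ethyl on an oxygen next to a carbonyl group). For the measured compounds named here, no measured pair shows this change. The expected step is a 29-fold lower number from compound 1 to compound 3 (1.46 log units; beyond the scatter) in this assay and would be a drop to a lower number, beyond the scatter. Going by the values given here, that expectation rests on compound 2 at 86000 nM as the only other measured value, so it is loosely anchored. For compound 3 the expected value is 150000 nM with an estimated range of 30000 nM to 800000 nM for this measurement.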

Compound 3, half-maximal effective concentration: 20000 nM
Compound 3: the middle estimate sits 7.5-fold (0.88 log units) above what was measured; the measured number lies below the stated range.
By their numbers in this assay, from the lowest: compound 3; then compound 2; then compound 1.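

In this assay, for the compounds shown here, hydrogen in place of ethyl on an oxygen next to a carbonyl group gives a 220-fold lower number from compound 1 to compound 3 (2.34 log units; beyond the scatter) and is the only step between measured compounds so far. This shows that the change from ethoxycarbonyl to carboxy, made at the end of the 2-(ethoxycarbonyl)ethenyl group, can by itself move the number far beyond the scatter. The size of this single change also exceeds what the earlier values alone had suggested. The data at hand offer no measurement that bears on why the number falls this far.

As far as these compounds go, whether an amide or a propyl ester at this place would stay close to compound 1 or to compound 3 remains open. Going by these compounds alone, with only one such pair, it is also open whether a step of this size would recur in another compound of the series.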